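Hydroxy in place of amino: estimating compound 4

The compounds below may be only part of what the source reports. "The series", "measured", "known", "first", "only" and "open" are said of these compounds alone.

Measured in a functional assay on KB cells (Homo sapiens) for antiproliferative activity, with a stated time of 72 h; on this read-out lower numbers stand for stronger inhibition and higher numbers for weaker inhibition:
compound 1 `COc1ccc(-n2ccc3c(OC)c(OC)c(OC)cc32)cc1` gives 186 nM
compound 2 `COc1ccc(-n2ccc3c(OC)c(OC)c(OC)cc32)c(N)c1` gives 102 nM
compound 3 `COc1ccc(-n2ccc3c(OC)c(OC)c(OC)cc32)cc1N` gives 3250 nM

Compound 3 stands apart from the other two, with the highest number of the three. Compound 4 `COc1ccc(-n2ccc3c(OC)c(OC)c(OC)cc32)cc1O` differs from it in a single group, hydroxy in place of amino on an aromatic carbon, and the count of that change is hydroxy in place of amino on an aromatic carbon in full.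

For the measured compounds named here, no measured step makes this exchange, so the evidence is indirect. The closest step is a 17-fold higher number from compound 1 to compound 3 (1.24 log units; beyond the scatter), a large one that puts amino on the same carbon that carries hydroxy in compound 4. The other step, a 1.8-fold lower number from compound 1 to compound 2 (0.26 log units; within the scatter), puts amino at a different place and stays within the scatter, so it bears on compound 4 only weakly. Together they show that the same exchange gives different outcomes at its two places. How hydroxy behaves on this carbon has not been measured.

A moderate step is therefore expected, recovering part of the large rise but not all of it. An estimated 4.1-fold lower number from compound 3 to compound 4 (0.61 log units; beyond the scatter) is expected in this assay and remains uncertain. For compound 4 the expected value is 800 nM, with an estimated range of 150 nM to 4000 nM around it.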

Compound 4, half-maximal inhibitory concentration: 131 nM
Beside the measured number, compound 4's estimate is 6.1-fold (0.79 log units) above it; the measured number lies below the stated range.
By their numbers in this assay, from the lowest: compounds 2, 4 and 1 (each within the scatter of the next); then compound 3.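

In this assay the exchange gives a 25-fold lower number from compound 3 to compound 4 (1.39 log units; beyond the scatter) and so shows that the large rise seen with amino on this carbon does not carry over to hydroxy, even though the two groups match in what is counted: one heavy atom, one hydrogen-bond donor, one hydrogen-bond acceptor and no net charge. The second step, a 1.4-fold lower number from compound 1 to compound 4 (0.15 log units; within the scatter), lies within the scatter, so this carbon, ortho to a methoxy group, can bear a hydroxy group with no change that can be read, and the loss in compound 3 goes with amino rather than with every group placed here. No measurement shown bears on why these two groups part so sharply.

From the compounds shown here alone, it remains open whether other groups on this carbon, such as a fluorine atom, a carboxylic acid or an ethoxy chain, would stay with compound 4 or move towards compound 3. Going by these compounds, it is also open how hydroxy would behave on the carbon that carries amino in compound 2, where amino itself gives a step within the scatter.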